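A few compounds are considered here, and "the series" means these few. Any claim that something is new, unique, unknown or untested is made for them only; others in the source may bear on it.

Of the compounds shown here, three built on a shared core have been measured in a physicochemical assay for solubility, read by nephelometry, measured as kinetic solubility; on this read-out lower numbers stand for lower solubility and higher numbers for higher solubility. Compound 1 `COc1ccc(Nc2nc(C)cc(N(C)C)n2)cc1` in this assay gives > 250000 nM, which is a limit of the assay and not a number. Compound 2 `COc1cc(Nc2nc(C)cc(N(C)C)n2)ccc1F` in this assay gives > 250000 nM, again a limit rather than a number. Compound 3 `Cc1cc(N(C)C)nc(N[C@H](C)c2ccccc2)n1` in this assay likewise gives > 250000 nM, a limit. Within the data shown here, compound 2 therefore stands where the other two stand, at the limit of the assay, a position described by the limit of > 250000 nM in this assay, at which 3 of the 3 values shown sit; no step between measured compounds can be drawn from such values.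

Compound 4 `COc1cc(Nc2nc(C)cc(NCc3ccccc3)n2)ccc1F` has not yet been measured. It differs from compound 2 in one place: benzylamino in place of dimethylamino on an aromatic carbon. Among the measured compounds shown here, since compound 2 sits at a limit, no measured step guides the expectation. The author expects the step in this assay from compound 2 to compound 4 to run downward, beyond the usual scatter, by about an at least 3.1-fold lower number from compound 2 to compound 4 (0.49 log units; beyond the scatter). Compound 4 is accordingly estimated to give 80000 nM in this assay, with a range from 20000 nM to 250000 nM.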

Compound 4, solubility: > 250000 nM
Compound 4 was reported as a limit; the forecaster's own chance of this, stated with the estimate: 35%; middle value at least 3.1-fold (0.49 log units) from the limit.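

No step from compound 2 to compound 4 can be read in this assay, since both compounds stand at the same limit, which is not a number: the limit of > 250000 nM in this assay, at which 4 of the 4 values shown sit.

The compounds shown leave open whether any change on the shared core would give a value that can be read as a number.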